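The source may report more compounds than this note shows. Statements on the series, on what has been measured and on what is new or still open speak of the compounds shown alone.

Compound 1 `Cc1ccccc1CN1CCc2c(sc(NC(=O)c3ccccc3Cl)c2C(N)=O)C1` is the starting point of this pair. In a functional assay on HL-60 cells (Homo sapiens) for antiproliferative activity, with a stated time of 24 h (on this read-out higher numbers stand for weaker inhibition and lower numbers for stronger inhibition), compound 1 gives only a limit, > 50000 nM, and no number; it sits at the limit of > 50000 nM in this assay, at which 1 of the 2 values shown sits. Among the measured compounds shown here, compound 2 `N#Cc1ccccc1CN1CCc2c(sc(NC(=O)c3ccccc3Cl)c2C(N)=O)C1` is the sole measured neighbour; in this assay compound 2 gives 10400 nM. For the measured compounds named here, that step, an at least 4.8-fold lower number from compound 1 to compound 2 (0.68 log units; beyond the scatter), is the only measured change on this ring, and it moves the read-out to a real number. Compound 3 `NC(=O)c1c(NC(=O)c2ccccc2Cl)sc2c1CCN(Cc1cc(Cl)cc(Cl)c1)C2` carries the change (3,5-dichlorophenyl in place of 2-methylphenyl on a saturated chain carbon bound to an amine nitrogen in a ring). Going by the values given here, no measured step exchanges 2-methylphenyl for 3,5-dichlorophenyl, so the step from compound 1 to compound 2 is the only guide, and it shows that altering this ring can bring the value down from the limit of compound 1. For compound 3 the estimate is 20000 nM, within 6000 nM to 50000 nM. The expected step is an at least 2.5-fold lower number from compound 1 to compound 3 (0.39 log units; beyond the scatter), with a real chance that compound 3 also returns only a limit.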

Compound 3, half-maximal inhibitory concentration: 15800 nM
For compound 3 the middle estimate is 1.3-fold (0.10 log units) above the measured one; the range from low to high includes it.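

In this assay, among the compounds shown here, 3,5-dichlorophenyl in place of 2-methylphenyl gives an at least 3.1-fold lower number from compound 1 to compound 3 (0.50 log units; beyond the scatter), so 2-cyanophenyl is no longer the only group at this place that returns a real number. The change from 2-cyanophenyl to 3,5-dichlorophenyl gives a 1.5-fold higher number from compound 2 to compound 3 (0.18 log units; within the scatter), so these two groups cannot be told apart here, even though one carries a nitrile and the other two chlorines. Compound 1 remains a limit and not a number: the limit of > 50000 nM in this assay, at which 1 of the 3 values shown sits.

Still open, going by these compounds, is how a phenyl carrying an amine or a carboxylic acid would read at this place, or a longer chain in place of the single saturated chain carbon. Only this one place varies among the compounds shown, so changes elsewhere on the core of compound 1 also remain open.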